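Swapping a nitrophenyl for a dihydroxyphenyl: cytotoxicity outlook

The source may report more compounds than this note shows. Statements on the series, on what has been measured and on what is new or still open speak of the compounds shown alone.

Three compounds have so far been measured in an ADME assay on THP-1 cells (Homo sapiens) for cytotoxicity; on this read-out higher numbers stand for weaker inhibition and lower numbers for stronger inhibition:

Compound 1, `COc1ccccc1-c1nnc(-c2ccc(C(=O)N/N=C/c3ccc([N+](=O)[O-])cc3)cc2)o1`, gives 203000 nM.
Compound 2, `COc1ccccc1-c1nnc(-c2ccc(C(=O)N/N=C/c3cccc(O)c3)cc2)o1`, gives 398000 nM.
Compound 3, `COc1ccccc1-c1nnc(-c2ccc(C(=O)N/N=C/c3ccccc3[N+](=O)[O-])cc2)o1`, gives 161000 nM.

Compound 1 stands second highest of these three numbers. Its nearest neighbour is compound 3, with a 1.3-fold lower number from compound 1 to compound 3 (0.10 log units; within the scatter); its furthest is compound 2, with a 2.0-fold higher number from compound 1 to compound 2 (0.29 log units; within the scatter). Among the measured compounds shown here, the only step that reaches beyond the scatter is a 2.5-fold lower number from compound 2 to compound 3 (0.39 log units; beyond the scatter), and even that is modest, so all three compounds sit close together in this assay.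

The unmeasured compound 4, `COc1ccccc1-c1nnc(-c2ccc(C(=O)N/N=C/c3cccc(O)c3O)cc2)o1`, differs from compound 1 in a single place: 2,3-dihydroxyphenyl in place of 4-nitrophenyl on a carbon with a double bond to nitrogen. The step that bears most on this change is a 2.0-fold higher number from compound 1 to compound 2 (0.29 log units; within the scatter), in which a 3-hydroxyphenyl likewise replaced the 4-nitrophenyl and the number rose only within the scatter. Compound 4 carries a 2,3-dihydroxyphenyl instead, a change of the same kind. The expectation in this assay is therefore a small rise at most, probably nothing beyond the scatter, giving a 1.5-fold higher number from compound 1 to compound 4 (0.17 log units; within the scatter).

Compound 4 is thus estimated at 300000 nM, with a likely range from 150000 nM to 600000 nM.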

Compound 4, half-maximal inhibitory concentration: 102000 nM
Estimate against measurement, compound 4: 2.9-fold (0.47 log units) above, and the stated range ends above it.
By their numbers in this assay, from the lowest: compounds 4, 3, 1 and 2 (each within the scatter of the next, the first and the last beyond it).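

In this assay, one added hydroxy on an aromatic carbon is enough to move the number beyond the scatter (a 3.9-fold lower number from compound 2 to compound 4 (0.59 log units; beyond the scatter)), although this step is modest, so the ring at this position is sensitive to a very small change. Replacing either nitrophenyl with 2,3-dihydroxyphenyl, however, stays within the scatter (a 2.0-fold lower number from compound 1 to compound 4 (0.30 log units; within the scatter); a 1.6-fold lower number from compound 3 to compound 4 (0.20 log units; within the scatter)), which shows that this replacement, with its hydrogen-bond donors in place of a nitro group, need not shift the result much, and that a ring bearing hydroxy groups does not necessarily sit at the high end of the series. Nothing available here explains why the added hydroxy has this effect.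

The compounds shown do not separate the contribution of each hydroxy, since a 2-hydroxyphenyl on the same carbon would be needed to tell whether the second hydroxy matters only alongside the first. They also leave open whether a methoxy or an amine on this ring would follow the hydroxy compounds or the nitro compounds.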